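The source may report more compounds than this note shows. Statements on the series, on what has been measured and on what is new or still open speak of the compounds shown alone.

Compound 1 `CS(=O)(=O)Nc1cccc2c1CCCCC2c1c[nH]cn1` — 2510 nM
Compound 2 `O=S(=O)(Nc1cccc2c1CCCC2c1c[nH]cn1)C1CC1` — 2690 nM
Compound 3 `CCS(=O)(=O)Nc1cccc2c1CCCC2(O)c1c[nH]cn1` — a limit, < 10000 nM

Of the compounds shown here, three on a shared core have been tested in an assay on isolated protein for binding affinity to Alpha-1D adrenergic receptor (Rattus norvegicus), read by radioligand binding; a higher number here means a weaker inhibitor, a lower number a stronger inhibitor. Compound 1 gives 2510 nM, and compound 2 gives 2690 nM; these two numbers sit within the usual scatter of each other, so neither compound can be placed ahead of the other. For compound 3 the assay returns only a limit, < 10000 nM, not a number; the limit of < 10000 nM in this assay, at which 1 of the 3 values shown sits, records it. Among the measured compounds shown here, no pair of measured compounds differs in a single place, so no measured step is at hand.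

The step from compound 2 to compound 4 `CC(=O)Nc1cccc2c1CCCC2c1c[nH]cn1` alters the group carried on the ring nitrogen: acetyl in place of cyclopropylsulfonyl on a nitrogen on an aromatic ring. No measured compound carries an acetamido group, so this exchange has no precedent among the numbers shown. The author expects the step of a 2.0-fold higher number from compound 2 to compound 4 (0.31 log units; beyond the scatter) to run toward a higher number and to lie beyond the scatter, though not by a wide margin. In this assay compound 4 is estimated at 5500 nM, with a range from 1800 nM to 16000 nM.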

Compound 4, inhibition constant: < 10000 nM
Compound 4 ended at the assay's limit; the forecaster's own chance of this, stated with the estimate: 30%; the middle value is on the limit's open side.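

In this assay compound 4 returns only a limit, not a number, so no step from compound 2 to compound 4 can be read: the limit of < 10000 nM in this assay, at which 2 of the 4 values shown sit.

The compounds shown leave open how acetyl compares with cyclopropylsulfonyl on a nitrogen on an aromatic ring.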